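Allyl-anisole esters: fluorine position swap on the aroyl group

This account rests on a few compounds, and the source may have more. Where it says the series, first, only, none or still open, it means among the compounds named here.

Measured compounds in a physicochemical assay for lipophilicity; on this read-out lower numbers stand for lower lipophilicity and higher numbers for higher lipophilicity:
compound 1 `C=CCc1ccc(OC(=O)C2CCCCC2)c(OC)c1`: 3.52
compound 2 `C=CCc1ccc(OC(=O)c2cccc(F)c2)c(OC)c1`: 2.7
compound 3 `C=CCc1ccc(OC(=O)c2ccc(Cl)cc2)c(OC)c1`: 2.79

Compound 2 stands lowest of the three numbers in this assay. Its nearest neighbour is compound 3, and the step of a number 0.09 log units higher from compound 2 to compound 3 (within the scatter) lies within the scatter, so the two are not separated. The step of a number 0.82 log units lower from compound 1 to compound 2 (beyond the scatter) is beyond the scatter, as is a number 0.73 log units lower from compound 1 to compound 3 (beyond the scatter); both replace cyclohexyl with a substituted phenyl on the carbonyl carbon.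

Compound 4 `C=CCc1ccc(OC(=O)c2ccccc2F)c(OC)c1` is the next member: 2-fluorophenyl in place of 3-fluorophenyl on a carbonyl carbon. Among the measured compounds shown here, no measured step moves a fluorine within the ring; the only aryl-to-aryl step, from compound 2 to compound 3, exchanged halogen and position together and stayed within the scatter. The cyclohexyl-to-aryl steps do not bear on this change. The expected step is therefore a number 0.05 log units lower from compound 2 to compound 4 (within the scatter), none beyond the scatter in either direction. For compound 4 the estimated value in this assay is 2.65, with a range from 2.3 to 3.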

Compound 4, partition coefficient: 2.7
Estimate against measurement, compound 4: 0.05 log units below; low and high end bracket the measured number.
By their numbers in this assay, from the lowest: compounds 2, 4 and 3 (each within the scatter of the next); then compound 1.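

In this assay, among the compounds shown here, 2-fluorophenyl in place of 3-fluorophenyl on the carbonyl carbon gives no change at the digits printed from compound 2 to compound 4 (within the scatter) and is the first step that changes only where the fluorine sits, so these two placements are not separated. The comparison with the 4-chlorophenyl ester reads a number 0.09 log units lower from compound 3 to compound 4 (within the scatter) and the comparison with the cyclohexyl ester reads a number 0.82 log units lower from compound 1 to compound 4 (beyond the scatter) so compound 4 joins compound 2 and compound 3 as a group of aryl esters not separated from one another, with compound 1 apart from all three. Nothing at hand accounts for the fluorine's place leaving the reading unseparated.

As far as these compounds go, whether an amine or a carboxylic acid in place of the fluorine would stand apart from these aryl esters in this assay remains open. So does the reading for a longer chain on the carbonyl carbon.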